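A new ring on the sulfonyl sulfur of compound 1

A few compounds are considered here, and "the series" means these few. Any claim that something is new, unique, unknown or untested is made for them only; others in the source may bear on it.

For the measured compounds named here, in a physicochemical assay for solubility, in simulated intestinal fluid, with a stated time of 4 h (a lower number here means a less soluble compound, a higher number a more soluble compound), compound 1 `N#Cc1ccc(O[C@H]2CN(S(=O)(=O)c3ccc(Cl)cc3Cl)C[C@@]2(O)CO)cc1F` gives 19 ug/mL and stands lowest of the three numbers so far. Compound 2 `N#Cc1ccc(O[C@H]2CN(S(=O)(=O)c3ccc(Cl)cc3Cl)C[C@@]2(O)CN)cc1F` gives 78 ug/mL and compound 3 `N#Cc1ccc(O[C@H]2CN(S(=O)(=O)c3ccc(Cl)cc3Cl)C[C@]2(O)CO)cc1F` gives 88 ug/mL in the same measurement. Placing amino instead of hydroxy on a chain carbon brings a 4.1-fold higher number from compound 1 to compound 2 (0.61 log units; beyond the scatter) and counts as a modest step. Changing one stereocentre brings a 4.6-fold higher number from compound 1 to compound 3 (0.67 log units; beyond the scatter) and is also modest, a step that rests on the fact that compounds 1 and 3 differ only in the configuration as drawn alone.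

Compound 4 `N#Cc1ccc(O[C@H]2CN(S(=O)(=O)c3ccc(Cl)cn3)C[C@@]2(O)CO)cc1F` has not been measured. It keeps the core of compound 1 and differs at the sulfonyl sulfur: 5-chloropyridin-2-yl in place of 2,4-dichlorophenyl on a sulfonyl sulfur with 5-chloropyridin-2-yl in place of 2,4-dichlorophenyl. Neither measured step touches this group, so those steps offer only a sense of scale. Going by the values given here, a modest rise is expected, starting from compound 1 at 19 ug/mL as the lowest number so far. The expected change is a 2.4-fold higher number from compound 1 to compound 4 (0.37 log units; beyond the scatter) and remains an estimate. Compound 4 is expected at 45 ug/mL within an estimated range of 15 ug/mL to 130 ug/mL in this assay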

Compound 4, solubility: 26 ug/mL
For compound 4 the middle estimate is 1.7-fold (0.24 log units) above the measured one; the measured number falls inside the stated range.
By their numbers in this assay, from the lowest: compounds 1 and 4 (each within the scatter of the next); then compounds 2 and 3 (each within the scatter of the next).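

In this assay, the swap gives a 1.4-fold higher number from compound 1 to compound 4 (0.14 log units; within the scatter), so the two compounds cannot be told apart in this measurement. For the compounds shown here, this is the first look at the group on the sulfonyl sulfur, as the earlier steps changed other parts of the molecule. Here, 5-chloropyridin-2-yl, with one chlorine and a ring nitrogen, takes the place of 2,4-dichlorophenyl, with two chlorines, and the number stays within the usual scatter. Nothing available here explains this outcome at this position.

The compounds shown leave open whether a group of a different kind on the sulfonyl sulfur, such as a pyridine ring carrying a carboxylic acid or a morpholine ring, would move the number beyond the scatter. They also leave open whether this same swap would behave alike when made on compound 2 or compound 3.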